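A few compounds are considered here, and "the series" means these few. Any claim that something is new, unique, unknown or untested is made for them only; others in the source may bear on it.

Compound 1, `CC(C)(C)c1ccc(NC(=O)c2ccc(-c3ccccc3)cc2)cc1`, gives the highest number of the three compounds measured in a functional assay on Dorsal root ganglion for antagonist activity at transient receptor potential cation channel subfamily V member 1 (Rattus norvegicus) (on this read-out higher numbers stand for weaker inhibition and lower numbers for stronger inhibition), at 3600 nM. Compound 2, `CC(C)(C)c1ccc(NC(=O)c2ccc(-c3cccnc3)cc2)cc1`, gives 1300 nM, and compound 3, `CC(C)(C)c1ccc(NC(=O)c2ccc(-c3ccncc3)cc2)cc1`, gives 280 nM. Compound 4, `CC(C)(C)c1ccc(NC(=O)c2ccc(-c3cnccn3)cc2)cc1`, differs from compound 1 by pyrazin-2-yl in place of phenyl on an aromatic carbon. Among the measured compounds shown here, two measured steps bear on this change: a 2.8-fold lower number from compound 1 to compound 2 (0.44 log units; beyond the scatter) and a 13-fold lower number from compound 1 to compound 3 (1.11 log units; beyond the scatter), both beyond the scatter and both toward stronger inhibition. Replacing the phenyl with a six-membered aromatic ring bearing nitrogen has therefore lowered the number in every case seen here, by a modest to large amount. On that basis a modest step toward a lower number is expected, a 4.0-fold lower number from compound 1 to compound 4 (0.60 log units; beyond the scatter). For compound 4 the estimated value in this assay is 900 nM, with a range from 300 nM to 3000 nM.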

Compound 4, half-maximal inhibitory concentration: 1000 nM
Compound 4: the middle estimate sits 1.1-fold (0.05 log units) below what was measured, within the range that was stated.
By their numbers in this assay, from the lowest: compound 3; then compounds 4 and 2 (each within the scatter of the next); then compound 1.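

In this assay, pyrazin-2-yl on the aromatic carbon para to a large group also lowers the number relative to phenyl, with a 3.6-fold lower number from compound 1 to compound 4 (0.56 log units; beyond the scatter). A ring with two nitrogens therefore keeps this gain, but the count of ring nitrogens alone does not set the outcome: the change to pyrazin-2-yl gives a 1.3-fold lower number from compound 2 to compound 4 (0.11 log units; within the scatter), while a 3.6-fold higher number from compound 3 to compound 4 (0.55 log units; beyond the scatter) leaves pyridin-4-yl with the lower number.

Nothing available explains these differences. On these data alone, whether a pyrimidin-5-yl ring, or a phenyl ring carrying an amine, would reach a number below that of compound 3 remains open.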